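Urea-pyrimidine series: methoxy on the phenylurea

The source may hold more compounds than are shown below. What is called first, only, known or untested is meant among the compounds shown, and "the series" means these compounds.

Measured so far in a functional assay on A549 cells (Homo sapiens) for inhibition, with a stated time of 72 h; a higher number here means a weaker inhibitor, a lower number a stronger inhibitor:

compound 1, `COc1ccc(NC(=O)Nc2nc(Nc3cc(OC)cc(OC)c3)cc(Sc3c[nH]c4ccccc34)n2)cc1`, > 50000 nM
compound 2, `O=C(Nc1ccccc1)Nc1nc(Sc2c[nH]c3ccccc23)cc(N2CCN(c3ccccn3)CC2)n1`, 30300 nM

Among the measured compounds shown here, compound 2 is the only compound with a number in this assay, where compound 2 gives 30300 nM. Compound 1 reaches only a limit in this assay, (the limit of > 50000 nM in this assay, at which 1 of the 2 values shown sits), and no number. The two are not compared as a step, since they differ in more than one place.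

Compound 3, `COc1ccc(NC(=O)Nc2nc(Sc3c[nH]c4ccccc34)cc(N3CCN(c4ccccn4)CC3)n2)cc1`, is the next compound to be measured in this assay. It differs from compound 2 in one place: methoxy in place of hydrogen on an aromatic carbon. For the measured compounds named here, no measured step of this kind exists, so the size of the change is open. The expected step from compound 2 to compound 3 is a 1.0-fold lower number from compound 2 to compound 3 (0.00 log units; within the scatter), no larger than the usual scatter, in either direction. Compound 3 is therefore estimated at 30000 nM in this assay, with a range from 12000 nM to 75000 nM.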

Compound 3, half-maximal inhibitory concentration: > 50000 nM
Compound 3 ended at the assay's limit (the forecaster's own chance of this, stated with the estimate: 25%); middle value at least 1.6-fold (0.22 log units) away from the limit.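

Going from phenyl to 4-methoxyphenyl on the urea gives the first readable step of the series in this assay (an at least 1.6-fold higher number from compound 2 to compound 3 (0.21 log units; that floor lies within the scatter)). Compound 3 stands at a limit of the assay and has no number, so this step is only a floor: the methoxy brings no gain here, and no loss beyond the scatter can be claimed. The step from compound 1 to compound 3 cannot be read, and the limit now holds most of the values in this small set: the limit of > 50000 nM in this assay, at which 2 of the 3 values shown sit.

On these data alone, how far the number for compound 3 lies from that of compound 2 remains open. Also open, as far as these compounds go, is how a fluorine, a chlorine, a dimethylamino group or a carboxylic acid at the same place on the phenyl ring would read in this assay against the unsubstituted phenyl of compound 2.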